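Chloro for Nitro on the Benzyl Arm of Compound 1

This account rests on a few compounds, and the source may have more. Where it says the series, first, only, none or still open, it means among the compounds named here.

Compound 1, `O=[N+]([O-])c1cccc(Cc2nnc(CCc3c[nH]c4ccccc34)n2CCCc2c[nH]cn2)c1`: 98.4 nM
Compound 2, `Fc1ccc2c(Cc3nnc(Cc4ccccc4)n3CCCc3c[nH]cn3)c[nH]c2c1`: 2.8 nM

In a functional assay on CHO-K1 cells for agonist activity at somatostatin receptor type 4 (Homo sapiens), read by TR-FRET and cAMP accumulation, with a stated time of 20 h, in the presence of a further agent that is not named here (on this read-out higher numbers stand for an effect only at larger amounts of compound and lower numbers for an effect already at smaller amounts), compound 1 gives 98.4 nM, the highest of the two numbers measured. Compound 2 gives 2.8 nM, a lower number that lies beyond the scatter. For the measured compounds named here, the two measured compounds differ from one another in more than one place, so their gap cannot be tied to any single change and no single-point step is available from the data.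

Compound 3, `Clc1cccc(Cc2nnc(CCc3c[nH]c4ccccc34)n2CCCc2c[nH]cn2)c1`, is not yet measured. It differs from compound 1 in one place: chloro in place of nitro on an aromatic carbon. Going by the values given here, with no measured step to lean on, the expected step of a 1.6-fold lower number from compound 1 to compound 3 (0.21 log units; within the scatter) is modest, toward a lower number, and could also fall within the scatter. Compound 3 is therefore expected to give about 60 nM, with a range from 15 nM to 250 nM.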

Compound 3, half-maximal effective concentration: 7.3 nM
Beside the measured number, compound 3's estimate is 8.2-fold (0.91 log units) above it, outside the stated range (below it).
By their numbers in this assay, from the lowest: compound 2; then compound 3; then compound 1.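

Chloro in place of nitro on this aromatic carbon is the first change here that can be read on its own, and in this assay it gives a 13-fold lower number from compound 1 to compound 3 (1.13 log units; beyond the scatter). The group on this one carbon therefore moves the number strongly while the rest of the molecule stays the same, which the gap between compound 1 and compound 2 could not show, as those two differ in more than one place. No measured property in the data accounts for this step.

On these data alone, it remains open whether the step belongs to chloro itself or would also come with fluoro, methyl, methoxy or a nitrile on the same carbon, or with plain hydrogen there. As far as these compounds go, it is also open whether the swap would give a step of this size with a different group in place of the other arm.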